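The source may hold more compounds than are shown below. What is called first, only, known or untested is meant among the compounds shown, and "the series" means these compounds.

Measured so far in an ADME assay on HeLa cells (Homo sapiens) for cytotoxicity, read by MTT assay; a higher number here means a weaker inhibitor, a lower number a stronger inhibitor:
Compound 1 `COC(=O)CNC(=O)CCC(=O)Oc1ccc(C[C@H]2C(=O)OC[C@@H]2Cc2ccc(OC)c(OC)c2)cc1OC` gives 179000 nM here.
Compound 2 `COc1ccc(C[C@H]2COC(=O)[C@@H]2Cc2ccc(OCc3cn(Cc4ccc(F)cc4)nn3)c(OC)c2)cc1OC` gives 198000 nM here.
Compound 3 `COc1ccc(C[C@H]2COC(=O)[C@@H]2Cc2ccc(OCc3cn(-c4ccc(C)cc4)nn3)c(OC)c2)cc1OC` gives >= 600000 nM as a limit and not a number.

The position of compound 3 is known only as a limit: the data show the limit of >= 600000 nM in this assay, at which 1 of the 3 values shown sits, and nothing more exact for it. Compound 4 `COc1ccc(C[C@H]2COC(=O)[C@@H]2Cc2ccc(OCc3cn(Cc4ccccc4)nn3)c(OC)c2)cc1OC` has not yet been measured. Its difference from compound 3 is benzyl in place of 4-methylphenyl on an aromatic nitrogen and amounts to benzyl in place of 4-methylphenyl on an aromatic nitrogen.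

Among the compounds with values here, one measured step bears on this. It is an at least 3.0-fold higher number from compound 2 to compound 3 (0.48 log units; beyond the scatter) and it came with 4-methylphenyl in place of 4-fluorobenzyl on an aromatic nitrogen, beyond the scatter. As far as these compounds go, that step ends on a limit, so its true size remains open. Compound 4 runs the other way, although benzyl stands where compound 2 carries 4-fluorobenzyl. A step of similar size is therefore expected in this assay toward a lower number, bringing compound 4 into the region of compound 2 at 198000 nM on that scale. The expected change is an at least 2.4-fold lower number from compound 3 to compound 4 (0.38 log units; beyond the scatter) by this estimate. Compound 4 is expected to give 250000 nM within an estimated range from 110000 nM to 550000 nM when it is measured.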

Compound 4, half-maximal inhibitory concentration: 346000 nM
Compound 4: the middle estimate sits 1.4-fold (0.14 log units) below what was measured, within the range that was stated.
By their numbers in this assay, from the lowest: compounds 1, 2 and 4 (each within the scatter of the next). At a limit, above all of these: compound 3.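

In this assay, the step from 4-fluorobenzyl to 4-methylphenyl had changed both the substituent on the aromatic ring and the way that ring is attached to the aromatic nitrogen, and compound 4 allows these two changes to be read apart. Removing the fluoro alone, with hydrogen in place of fluoro on an aromatic carbon, gives a 1.7-fold higher number from compound 2 to compound 4 (0.24 log units; within the scatter), so this single change on the benzyl group has no readable effect here. Benzyl and 4-methylphenyl have the same atoms joined differently, and benzyl in place of 4-methylphenyl gives an at least 1.7-fold lower number from compound 3 to compound 4 (0.23 log units; that floor lies within the scatter), so this step does not yet separate the two groups, and its true size stays open, as compound 3 is held only at a limit: the limit of >= 600000 nM in this assay, at which 1 of the 4 values shown sits.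

As far as these compounds go, it remains open how phenyl or 4-methylbenzyl on the aromatic nitrogen would read in this assay, and these two groups could set the methyl apart from the way the ring is attached. Also open, from the compounds shown here alone, is whether an amine or a carboxylic acid on the benzyl ring would give a step from compound 4 beyond the scatter.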